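The compounds below may be only part of what the source reports. "The series", "measured", "known", "first", "only" and "open" are said of these compounds alone.

Measured so far in a functional assay for inhibition of Thromboxane-A synthase (Rattus norvegicus); on this read-out higher numbers stand for weaker inhibition and lower numbers for stronger inhibition:
compound 1 `O=C1c2ccccc2C(=O)N1CCCCCCn1ccnc1` gives 1500 nM;
compound 2 `O=C1c2ccccc2C(=O)N1CCCCCCCCn1ccnc1` gives 200 nM.

Compound 2 stands at the lower of the two numbers; the only other point, compound 1, sits well away from it. Within the data shown here, the single step measured so far, a 7.5-fold lower number from compound 1 to compound 2 (0.88 log units; beyond the scatter), was a modest move to a stronger inhibitor, made by lengthening the saturated chain. Compound 3 `O=C1c2ccccc2C(=O)N1CCCCCCCCCCn1ccnc1` carries the same kind of change one stage further: 2-(1H-imidazol-1-yl)ethyl in place of 1H-imidazol-1-yl on a saturated chain carbon, eight bonds along the chain from an amide-type nitrogen in a ring. Among the measured compounds shown here, only that one step bears on the question, and nothing yet shows whether further lengthening keeps helping or levels off, so the expectation leans on a single data point. For compound 3 the step of a 2.2-fold lower number from compound 2 to compound 3 (0.35 log units; beyond the scatter) is expected to be a lower number again, probably smaller than the earlier one. Compound 3 is therefore estimated at 90 nM, with a range from 25 nM to 350 nM.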

Compound 3, half-maximal inhibitory concentration: 100 nM
Compound 3: middle estimate off by 1.1-fold (0.05 log units), on the low side; measured number inside the range.
By their numbers in this assay, from the lowest: compounds 3 and 2 (each within the scatter of the next); then compound 1.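

In this assay, the same lengthening of the chain now gives a 2.0-fold lower number from compound 2 to compound 3 (0.30 log units; within the scatter), so this further change cannot be told apart from the ordinary spread of repeated measurements. Among these compounds, the earlier step, a 7.5-fold lower number from compound 1 to compound 2 (0.88 log units; beyond the scatter), was a clear gain, so this is the first sign that extending the chain at this position does not keep paying off at the same rate, with compound 2 and compound 3 level within the scatter. Nothing measured here offers an explanation for this behaviour.

As far as these compounds go, it remains open whether a chain longer than that of compound 3 would stay level, give a lower number or give a higher one. From the compounds shown here alone, it is also open whether an ether oxygen within the chain, or a pyridine ring in place of the imidazole, would follow the same trend.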